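The compounds below may be only part of what the source reports. "The series", "measured", "known", "first", "only" and "open" are said of these compounds alone.

Values in a functional assay on DU-145 cells (Homo sapiens) for cytotoxicity, read by trypan blue exclusion, with a stated time of 96 h; a higher number here means a weaker inhibitor, a lower number a stronger inhibitor:
compound 1 `COc1cc(OC)c(/C=C/S(=O)(=O)Cc2ccc(OC)cc2[N+](=O)[O-])c(OC)c1`: 20000 nM
compound 2 `COc1ccc(CS(=O)(=O)/C=C/c2c(OC)cc(OC)cc2OC)c(N)c1`: 25 nM
compound 3 `COc1cc(OC)c(/C=C/SCc2ccc(OC)c([N+](=O)[O-])c2)c(OC)c1`: 5000 nM

Compound 2 differs from compound 1 by amino in place of nitro on an aromatic carbon; this change gave an 800-fold lower number from compound 1 to compound 2 (2.90 log units; beyond the scatter). Compound 3 carries a different core; the difference between the two cores is not broken down here. Its value stands between the other two: higher than compound 2, lower than compound 1.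

Compound 4 `COc1cc(OC)c(/C=C/SCc2ccc(OC)c(N)c2)c(OC)c1` is not yet measured. It differs from compound 3 by amino in place of nitro on an aromatic carbon. This is the same kind of change as that from compound 1 to compound 2, not the same: in compound 2 the amino sits ortho to a large group and meta to a methoxy group, in compound 4 ortho to a methoxy group and meta to a large group.

A large downward step is expected from compound 3 to compound 4, a 63-fold lower number from compound 3 to compound 4 (1.80 log units; beyond the scatter), resting on an 800-fold lower number from compound 1 to compound 2 (2.90 log units; beyond the scatter). The different core and the different surroundings of the amino leave room for a smaller step, so the range is set wide. Compound 4 is estimated at 80 nM, between 8 nM and 800 nM.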

Compound 4, half-maximal inhibitory concentration: 50 nM
The estimate for compound 4 lay 1.6-fold (0.20 log units) above the measured number; measured number inside the range.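

In this assay amino in place of nitro again brings a large drop (a 100-fold lower number from compound 3 to compound 4 (2.00 log units; beyond the scatter)), so across these two pairs the direction of the change carries over from the core of compound 1 to the core of compound 3. The size of the step, however, does not stay the same from one core to the other: the same change on two cores in this assay, an 800-fold lower number (2.90 log units; beyond the scatter) from compound 1 to compound 2 and a 100-fold lower number (2.00 log units; beyond the scatter) from compound 3 to compound 4, 8.0-fold (0.90 log units) apart, beyond the scatter of two such steps

The two pairs differ both in core and in the surroundings of the amino, so the gap cannot be assigned to either difference, and two pairs do not establish a rule for further cores.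

Open, on these data alone, is whether the low numbers of compound 2 and compound 4 depend on the amino itself, or whether a hydroxyl group, a methylamino group or an acetamide in the same place would give similar values. Also open, as far as these compounds go, is how the step would turn out with the amino placed as in compound 2 on the core of compound 4, a pair that would separate the effect of core from that of surroundings.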